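The source may report more compounds than this note shows. Statements on the series, on what has been measured and on what is new or still open speak of the compounds shown alone.

Compound 3, `C#CCNC1CCc2c(SCc3ccc(Cl)c(Cl)c3)cccc21`, is measured in an assay on isolated protein for inhibition of Amine oxidase [flavin-containing] B (Homo sapiens) (a lower number here means a stronger inhibitor, a higher number a weaker inhibitor), and gives 2840 nM. Among the three measured compounds this is the highest number: compound 1, `C#CCNC1CCc2c(SCc3cccc(F)c3)cccc21`, gives 1480 nM, and compound 2, `C#CCNC1CCc2c(SCc3ccc(Br)cc3)cccc21`, gives 1310 nM. Compound 4, `C#CCNC1CCc2c(SCc3cccc(Cl)c3)cccc21`, has not been measured; it differs from compound 3 by hydrogen in place of chloro on an aromatic carbon, the change sitting on an aromatic carbon of a six-membered aromatic ring of carbon only, ortho to a chloro group and para to a large group. Among the compounds with values here, the only measured single step, a 1.1-fold lower number from compound 1 to compound 2 (0.05 log units; within the scatter), swaps one halophenyl for another and does not repeat this change, so no direct precedent exists. Since compound 1 and compound 2, each carrying a single halogen on that ring, both sit below compound 3, a modest move toward lower numbers is expected, of about a 1.8-fold lower number from compound 3 to compound 4 (0.25 log units; within the scatter), though it may fall within the scatter. Compound 4 is therefore estimated at 1600 nM, in the range 700 nM to 3600 nM.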

Compound 4, half-maximal inhibitory concentration: 23300 nM
The estimate for compound 4 lay 15-fold (1.16 log units) below the measured number, outside the stated range (above it).
By their numbers in this assay, from the lowest: compounds 2, 1 and 3 (each within the scatter of the next, the first and the last beyond it); then compound 4.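

In this assay, hydrogen in place of chloro on this aromatic carbon, ortho to a chloro group and para to a large group, gives an 8.2-fold higher number from compound 3 to compound 4 (0.91 log units; beyond the scatter), so this carbon is sensitive to the change even though the remaining chloro stays in place. Carrying a single halogen on the ring does not fix the level either: chloro in place of fluoro gives a 16-fold higher number from compound 1 to compound 4 (1.20 log units; beyond the scatter), 3-chlorophenyl in place of 4-bromophenyl gives an 18-fold higher number from compound 2 to compound 4 (1.25 log units; beyond the scatter), and yet the earlier step between two single-halogen compounds was only a 1.1-fold lower number from compound 1 to compound 2 (0.05 log units; within the scatter). Nothing available explains these gaps.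

The compounds shown leave open whether a methyl or methoxy group on this carbon would restore the lower numbers as chloro does. They also leave open whether a bromo group there would behave like chloro.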